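The compounds below may be only part of what the source reports. "The series", "measured", "known", "first", "only" and "open" are said of these compounds alone.

Compound 2, with the structure `Nc1cccc(CO[C@@H]2C[C@@H]3[C@H]([C@]2(N)C(=O)O)[C@@]3(F)C(=O)O)c1`, gives the higher of the two numbers recorded so far in an assay on CHO cells for binding affinity to metabotropic glutamate receptor 2 (Rattus norvegicus) (on this read-out higher numbers stand for weaker inhibition and lower numbers for stronger inhibition), where compound 2 reaches 15.4 nM. Its nearest neighbour is compound 1, `N[C@]1(C(=O)O)[C@H]2[C@@H](C[C@H]1OCc1cccc(Br)c1)[C@]2(F)C(=O)O`, which in this assay gives 4.71 nM; the step of a 3.3-fold higher number from compound 1 to compound 2 (0.51 log units; beyond the scatter) arose from the change amino in place of bromo on an aromatic carbon. Compound 3, `N[C@]1(C(=O)O)[C@H]2[C@@H](C[C@H]1OCc1ccc(Cl)cc1Cl)[C@]2(F)C(=O)O`, is not yet measured. It differs from compound 2 by 2,4-dichlorophenyl in place of 3-aminophenyl on a saturated chain carbon bound to an oxygen on a saturated carbon. Among the compounds with values here, the only measured step that bears on this change is a 3.3-fold higher number from compound 1 to compound 2 (0.51 log units; beyond the scatter), which went from a halogen to an amino group and raised the number modestly. Reversing that direction, from the amino group back to halogens, the expectation is a lower number for compound 3 of roughly the size seen between compounds 1 and 2, so that the expected step is a 3.1-fold lower number from compound 2 to compound 3 (0.49 log units; beyond the scatter). Compound 3 is therefore estimated at 5 nM in this assay, in a range from 1.5 nM to 20 nM.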

Compound 3, inhibition constant: 3.89 nM
The estimate for compound 3 lay 1.3-fold (0.11 log units) above the measured number, and the stated range covers the measured number.
By their numbers in this assay, from the lowest: compounds 3 and 1 (each within the scatter of the next); then compound 2.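

Replacing 3-aminophenyl with 2,4-dichlorophenyl on a saturated chain carbon bound to an oxygen on a saturated carbon gives a 4.0-fold lower number from compound 2 to compound 3 (0.60 log units; beyond the scatter) in this assay, so compound 2 now reads higher than two halogen-bearing compounds rather than one. Within the data shown here, exchanging 3-bromophenyl for 2,4-dichlorophenyl gives a 1.2-fold lower number from compound 1 to compound 3 (0.08 log units; within the scatter), so this read-out does not separate the single bromine of compound 1 from the two chlorines of compound 3. Nothing available explains why the amino-bearing ring of compound 2 stands apart from these halogen-bearing rings.

The compounds shown leave open whether the higher number goes with the amino group itself or with its place on the ring, as a 4-aminophenyl group could show. They also leave open how an unsubstituted phenyl group or a ring carrying a hydroxyl or a methoxy group would read.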